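The source may hold more compounds than are shown below. What is called first, only, known or untested is meant among the compounds shown, and "the series" means these compounds.

Compound 1 `CCN(CC)S(=O)(=O)c1ccc(S(=O)(=O)N2CCC[C@@H](C(=O)N3CCC(O)CC3)C2)cc1` is the weakest-looking of the three measured analogues on paper: in a functional assay on MIA PaCa-2 cells (Homo sapiens) for inhibition, read by MTT assay, with a stated time of 3 days (on this read-out higher numbers stand for weaker inhibition and lower numbers for stronger inhibition), compound 1 gives 230 nM, the highest of the three numbers, though none of its gaps to the others reaches beyond the scatter. Compound 2 `CCN(CC)S(=O)(=O)c1ccc(S(=O)(=O)N2CCC[C@@H](C(=O)N3CCOCC3)C2)cc1` gives 160 nM and compound 3 `CCN(CC)S(=O)(=O)c1ccc(S(=O)(=O)N2CCC[C@@H](C(=O)N3CCC(C(F)F)CC3)C2)cc1` gives 140 nM. The steps between them are all small: a 1.4-fold lower number from compound 1 to compound 2 (0.16 log units; within the scatter), a 1.6-fold lower number from compound 1 to compound 3 (0.22 log units; within the scatter) and a 1.1-fold lower number from compound 2 to compound 3 (0.06 log units; within the scatter).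

Compound 4 `CCN(CC)S(=O)(=O)c1ccc(S(=O)(=O)N2CCC[C@@H](C(=O)NC3CCOCC3)C2)cc1` differs from compound 1 by (oxan-4-yl)amino in place of 4-hydroxypiperidin-1-yl on a carbonyl carbon. Among the measured compounds shown here, the steps that bear on this are the two that alter the same region of compound 1, namely a 1.4-fold lower number from compound 1 to compound 2 (0.16 log units; within the scatter) and a 1.6-fold lower number from compound 1 to compound 3 (0.22 log units; within the scatter); both stayed within the scatter, and neither changed the amide from a tertiary to a secondary one, so no measured step covers that part of the change. On this evidence no step beyond the scatter is expected, with at most a slight lean toward a lower number. Compound 4 is therefore expected to give 190 nM, within a range of 80 nM to 450 nM. That expectation corresponds to a step of a 1.2-fold lower number from compound 1 to compound 4 (0.08 log units; within the scatter).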

Compound 4, half-maximal inhibitory concentration: 1350 nM
Compound 4: middle estimate off by 7.1-fold (0.85 log units), on the low side, and the stated range ends below it.
By their numbers in this assay, from the lowest: compounds 3, 2 and 1 (each within the scatter of the next); then compound 4.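

In this assay, among the compounds shown here, this position on the carbonyl carbon proves sensitive to how the ring is attached, which the earlier compounds did not show: (oxan-4-yl)amino in place of 4-hydroxypiperidin-1-yl gives (a 5.9-fold higher number from compound 1 to compound 4 (0.77 log units; beyond the scatter)), with the same atoms joined differently. The gap also holds against the other two ring amides (an 8.4-fold higher number from compound 2 to compound 4 (0.93 log units; beyond the scatter)) and (a 9.6-fold higher number from compound 3 to compound 4 (0.98 log units; beyond the scatter)), so among these four compounds only compound 4, the one amide with an amide hydrogen, stands apart from the rest. No measurement shown here accounts for this difference.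

The compounds shown leave open whether the higher number follows the amide hydrogen itself or the attachment of the ring through its carbon. A methyl group on that amide nitrogen, as in methyl(oxan-4-yl)amino, would bear on this, as would a cyclohexylamino group on the same carbonyl carbon.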